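Working notes: arylamino in place of aryl on the shared core

The compounds below may be only part of what the source reports. "The series", "measured", "known", "first", "only" and "open" are said of these compounds alone.

Measured compounds:
compound 1 `COc1cc(C(=O)c2sc3ccccc3c2-c2ccc(SC)cc2)cc(OC)c1OC` — in a functional assay on K562 cells (Homo sapiens) for antiproliferative activity, read by MTT assay, with a stated time of 72 h (a higher number here means a weaker inhibitor, a lower number a stronger inhibitor), compound 1 gives 1800 nM
compound 2 `COc1cc(C(=O)c2sc3ccccc3c2Nc2ccccc2)cc(OC)c1OC` — in this assay compound 2 gives 2300 nM

Within the data shown here, compound 1 has the lowest of the two numbers so far, but its only neighbour, compound 2, sits close: a 1.3-fold higher number from compound 1 to compound 2 (0.11 log units; within the scatter). The two values therefore cannot be ordered.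

The next compound, compound 3 `COc1ccc(Nc2c(C(=O)c3cc(OC)c(OC)c(OC)c3)sc3ccccc23)cc1`, differs from compound 1 in one place: (4-methoxyphenyl)amino in place of 4-(methylsulfanyl)phenyl on an aromatic carbon. Among the measured compounds shown here, the single measured step that bears on this is a 1.3-fold higher number from compound 1 to compound 2 (0.11 log units; within the scatter), where the same 4-(methylsulfanyl)phenyl group at the same aromatic carbon gave way to anilino; that step stayed within the scatter. Compound 3 carries the same amino linkage as compound 2, with a methoxy group on the entering ring. For the measured compounds named here, no measured pair shows what that methoxy group does on this ring, so the expectation rests on the anilino step alone.

For compound 3 the expected step from compound 1 is a 1.2-fold higher number from compound 1 to compound 3 (0.07 log units; within the scatter), no more than the scatter in either direction. The estimate for compound 3 in this assay is 2100 nM, with a range from 900 nM to 4800 nM.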

Compound 3, half-maximal inhibitory concentration: 2900 nM
Compound 3: middle estimate off by 1.4-fold (0.14 log units), on the low side; low and high end bracket the measured number.
By their numbers in this assay, from the lowest: compounds 1, 2 and 3 (each within the scatter of the next).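

In this assay, among these compounds, the entering ring carries a substituent for the first time, with methoxy in place of hydrogen on the ring of compound 2 (a 1.3-fold higher number from compound 2 to compound 3 (0.10 log units; within the scatter)). Among the compounds shown here, this gives the first measured reading of a change on that ring, and it does not separate the two compounds. The full exchange of 4-(methylsulfanyl)phenyl for (4-methoxyphenyl)amino, on the aromatic carbon two ring bonds from the ring sulfur, gives a second such reading (a 1.6-fold higher number from compound 1 to compound 3 (0.21 log units; within the scatter)), so two amino-linked compounds now lie within the scatter of compound 1. No supporting evidence on these results is available.

The compounds shown leave open whether anything at this position can move the number beyond the scatter, since every step so far stays within it and methoxy is the only substituent shown on the entering ring. Going by these compounds, it also remains open what a carboxylic acid or a dimethylamino group on that ring would do, or a longer alkyl chain on the linking nitrogen in place of the aromatic ring.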